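Methyl to ethyl on the amide of compound 1

A few compounds are considered here, and "the series" means these few. Any claim that something is new, unique, unknown or untested is made for them only; others in the source may bear on it.

In a functional assay on HeLa cells (Homo sapiens) for antiproliferative activity, read by CCK-8 assay, with a stated time of 72 h (a lower number here means a stronger inhibitor of growth, a higher number a weaker inhibitor of growth), compound 1 `CCC1C(=O)N(C)c2cnc(-n3ccc4cc(C(=O)NC)ccc43)nc2N1c1ccn(C)n1` gives 6330 nM and holds the higher of the two numbers. Compound 2 `CCCNS(=O)(=O)c1ccc(Nc2ncc3c(n2)N(c2ccn(C)n2)C(CC)C(=O)N3C)cc1` gives 2670 nM and lies lower, beyond the scatter. Compound 3 `CCNC(=O)c1ccc2c(ccn2-c2ncc3c(n2)N(c2ccn(C)n2)C(CC)C(=O)N3C)c1` differs from compound 1 by methyl in place of hydrogen on a saturated chain carbon bound to an amide-type nitrogen with methyl in place of hydrogen on a saturated chain carbon bound to an amide-type nitrogen, which also reads as methylcarbamoyl to ethylcarbamoyl. For the measured compounds named here, no measured pair shows this change, so the expectation is loose. The estimated 1.2-fold lower number from compound 1 to compound 3 (0.06 log units; within the scatter) is expected to stay within the scatter, with no firm direction. Compound 3 is expected at 5500 nM with an estimated range from 2200 nM to 13000 nM in this measurement.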

Compound 3, concentration for 50% growth inhibition: 11100 nM
The estimate for compound 3 lay 2.0-fold (0.30 log units) below the measured number; low and high end bracket the measured number.
By their numbers in this assay, from the lowest: compound 2; then compounds 1 and 3 (each within the scatter of the next).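

Methyl to ethyl on the amide of the shared core gives a 1.8-fold higher number from compound 1 to compound 3 (0.24 log units; within the scatter) in this assay and is the first single-place step read in this series. At this position, the added methyl therefore gives no change beyond the scatter, and compounds 1 and 3 cannot be separated. No available data bear on this result.

From the compounds shown here alone, a longer chain, such as propyl, or a chain carrying an amine on the amide nitrogen remains open. So does a carboxylic acid in place of the whole methylcarbamoyl group.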